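The source may hold more compounds than are shown below. What is called first, only, known or untested is meant among the compounds shown, and "the series" means these compounds.

Compound 2 (`CC(=O)OC1C(CCl)OC(n2c(Cl)nc3cc(Cl)c(Cl)cc32)C1OC(C)=O`) gives 32000 nM in a functional assay on HFF cells (Homo sapiens) for cytotoxicity (on this read-out lower numbers stand for stronger inhibition and higher numbers for weaker inhibition), and stands level with compound 1 (`CC(=O)OC1C(CF)OC(n2c(Cl)nc3cc(Cl)c(Cl)cc32)C1OC(C)=O`), which gives 32000 nM on the same read-out. The next compound to be tested is compound 3 (`CC(=O)OC1C(CBr)OC(n2c(Cl)nc3cc(Cl)c(Cl)cc32)C1OC(C)=O`). The change that leads to it is bromo in place of chloro on a saturated chain carbon bound to a saturated ring carbon and it amounts to bromo in place of chloro on a saturated chain carbon bound to a saturated ring carbon, or chloromethyl to bromomethyl when cut one bond further out. Within the data shown here, only one measured step bears on this, the exchange of chloro for fluoro at that same place, and it came out as no change at the digits printed from compound 1 to compound 2 (within the scatter) with no other halogen exchange available for comparison. Among the measured compounds shown here, that is a single step, and no bromo compound has been measured yet, so the basis is thin. Even so, no change beyond the scatter is expected in this assay for this exchange. The estimated move is a 1.1-fold lower number from compound 2 to compound 3 (0.06 log units; within the scatter) and no larger shift is anticipated. For compound 3 the expected value is 28000 nM with an estimated range of 12000 nM to 55000 nM on this read-out.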

Compound 3, half-maximal inhibitory concentration: 32000 nM
The estimate for compound 3 lay 1.1-fold (0.06 log units) below the measured number; the measured number falls inside the stated range.
By their numbers in this assay, from the lowest: compounds 1, 2 and 3 (each within the scatter of the next).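

In this assay, bromo in place of chloro on a saturated chain carbon bound to a saturated ring carbon gave no change at the digits printed from compound 2 to compound 3 (within the scatter), and bromo in place of fluoro at the same place gave no change at the digits printed from compound 1 to compound 3 (within the scatter). Among these compounds, the earlier compounds offered only one exchange at this position, whereas fluoro, chloro and bromo can now be compared directly, and across these three compounds the read-out does not separate the halogens, with none of them going against this pattern. Nothing available accounts for this flat result.

The compounds shown leave open whether iodo, a hydroxyl group or an amine on that chain carbon, or a longer chain in place of the halomethyl group, would also leave the read-out in this assay in the same place. They also leave open what free hydroxyl groups in place of the two acetyl groups on the shared core would do, as all three compounds carry those acetyl groups.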